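The source may report more compounds than this note shows. Statements on the series, on what has been measured and on what is new or still open speak of the compounds shown alone.

Measured compounds:
Compound 1, `CCC(=O)NCCCO[C@H]1[C@H](C)O[C@@H](O[C@H]2[C@H](C)[C@@H](O[C@@H]3O[C@H](C)C[C@H](N(C)C)[C@H]3O)[C@](C)(O)C[C@@H](C)CN(C)[C@H](C)[C@@H](O)[C@](C)(O)[C@@H](CC)OC(=O)[C@@H]2C)C[C@@]1(C)OC`: 2.54
Compound 2, `CC[C@H]1OC(=O)[C@H](C)[C@@H](O[C@H]2C[C@@](C)(OC)[C@@H](OCCCNC(=O)c3c(C)nn(C)c3Cl)[C@H](C)O2)[C@H](C)[C@@H](O[C@@H]2O[C@H](C)C[C@H](N(C)C)[C@H]2O)[C@](C)(O)C[C@@H](C)CN(C)[C@H](C)[C@@H](O)[C@]1(C)O`: 2.52
Compound 3, `CCC(=O)NCCCO[C@H]1[C@H](O[C@@H]2[C@@H](C)[C@H](O[C@H]3C[C@@](C)(OC)[C@@H](O)[C@H](C)O3)[C@@H](C)C(=O)O[C@H](CC)[C@@](C)(O)[C@H](O)[C@@H](C)N(C)C[C@H](C)C[C@@]2(C)O)O[C@H](C)C[C@@H]1N(C)C`: 2.7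

These three compounds were measured in a physicochemical assay for lipophilicity, read by HPLC, measured as chromatographic lipophilicity, at pH 7.4; a higher number here means a more lipophilic compound, a lower number a more polar compound. Compound 1 and compound 2 differ in one place, (5-chloro-1,3-dimethyl-1H-pyrazol-4-yl in place of ethyl on a carbonyl carbon), and that change gave a number 0.02 log units lower from compound 1 to compound 2 (within the scatter). Compound 3 has the same atoms as compound 1, joined differently; the difference between the two cores is not broken down here. In this assay compound 3 gives 2.7, which sits within the scatter of both compound 1 and compound 2, so no order among the three can be read from these numbers.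

Compound 4, `CC[C@H]1OC(=O)[C@H](C)[C@@H](O[C@H]2C[C@@](C)(OC)[C@@H](O)[C@H](C)O2)[C@H](C)[C@@H](O[C@@H]2O[C@H](C)C[C@H](N(C)C)[C@H]2OCCCNC(=O)c2c(C)nn(C)c2Cl)[C@](C)(O)C[C@@H](C)CN(C)[C@H](C)[C@@H](O)[C@]1(C)O`, is not yet measured. It is related to compound 3 by 5-chloro-1,3-dimethyl-1H-pyrazol-4-yl in place of ethyl on a carbonyl carbon, which is the same change as that from compound 1 to compound 2, made at a place described in the same words. Because the earlier step was a number 0.02 log units lower from compound 1 to compound 2 (within the scatter), the step from compound 3 to compound 4 is expected to be about a number 0.02 log units lower from compound 3 to compound 4 (within the scatter). Compound 4 is therefore estimated to give 2.68 in this assay, with a likely range from 2.3 to 3.1.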

Compound 4, distribution coefficient: 3.08
The estimate for compound 4 lay 0.40 log units below the measured number; low and high end bracket the measured number.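

In this assay, putting 5-chloro-1,3-dimethyl-1H-pyrazol-4-yl in place of ethyl on a carbonyl carbon gave a number 0.38 log units higher from compound 3 to compound 4 (beyond the scatter), whereas the same change on the core of compound 1 gave a number 0.02 log units lower from compound 1 to compound 2 (within the scatter). The step measured on one core therefore did not carry over in size to the other in this pair of cores, and a step that lay within the scatter on the first core lay beyond it on the second. With a single pair on each core, this shows only that the step can depend on the core, not that it always does or how far it would differ for other groups, and nothing shown here accounts for the difference.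

The compounds shown leave open whether the two cores would also part ways with another group on the carbonyl carbon, such as phenyl or a chain longer than ethyl. They also leave open how a group carrying an amine or a carboxylic acid would behave there on each core.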